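The compounds below may be only part of what the source reports. "The series", "measured", "known", "first", "only" and "open" are said of these compounds alone.

Of the compounds shown here, two have been measured in a functional assay on CHO cells for antagonist activity at sphingosine 1-phosphate receptor 2 (Homo sapiens), read by fluorescence and calcium flux, with a stated time of 3 min; on this read-out higher numbers stand for weaker inhibition and lower numbers for stronger inhibition. Compound 1, with structure `Cc1cc(NNC(=O)Nc2cc(Cl)nc(Cl)c2)nc(-c2ccc(F)cc2)c1`, gives 1300 nM in this assay. Compound 2, with structure `CCOc1cc(NC(=O)NCc2cc(C)c(-c3cn(C)nc3C(F)(F)F)nn2)cc(C)n1`, gives 54000 nM in this assay, the higher of the two numbers, and the gap between compound 2 and compound 1 lies well beyond the usual scatter, so compound 2 is the weaker inhibitor of the pair.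

Compound 3, with structure `CCOc1nc(C)cc(NC(=O)NCc2cc(C)c(-c3cn(C)nc3C(F)(F)F)nn2)c1Cl`, has not yet been measured. It differs from compound 2 in one place: chloro in place of hydrogen on an aromatic carbon ortho to an ethoxy group, two atoms from the ring nitrogen, in a pyridinyl part of the molecule that carries no other change. Within the data shown here, nothing among the measured compounds shows what such a single substitution does in this assay, and the two measured structures differ in many places at once, so no step can be read across from them.

Compound 3 is therefore expected to stay close to compound 2, with the step of a 1.4-fold lower number from compound 2 to compound 3 (0.13 log units; within the scatter) small and in no firm direction, and its estimated value in this assay is 40000 nM, within a range of 10000 nM to 150000 nM.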

Compound 3, half-maximal inhibitory concentration: 8700 nM
The estimate for compound 3 lay 4.6-fold (0.66 log units) above the measured number, and the stated range ends above it.
By their numbers in this assay, from the lowest: compound 1; then compound 3; then compound 2.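

The change from hydrogen to chloro on this aromatic carbon, ortho to an ethoxy group and two atoms from the ring nitrogen, is not silent in this assay: it gives a 6.2-fold lower number from compound 2 to compound 3 (0.79 log units; beyond the scatter), a modest step towards stronger inhibition. Among these compounds, until now no pair of compounds differing in one place had been available, so this is the first sign that this position of the 2-ethoxy-6-methylpyridin-4-yl part responds to a single added chlorine atom with the rest of the molecule unchanged. No measurement among the compounds shown says what lies behind this step.

From the compounds shown here alone, it remains open whether the step belongs to chloro in particular or would also follow from another group on the same carbon, such as fluoro, bromo, methyl or a nitrile. It is equally open whether the chloro step would hold if the neighbouring ethoxy group gave way to a methoxy group or a longer alkoxy chain, since the only step shown was taken with ethoxy in place.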